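Swapping an amino link for a larger ether group

The source may report more compounds than this note shows. Statements on the series, on what has been measured and on what is new or still open speak of the compounds shown alone.

Of the compounds shown here, three have so far been measured in a functional assay on RS4-11 cells (Homo sapiens) for inhibition, read by CCK-8 assay, with a stated time of 72 h; on this read-out lower numbers stand for stronger inhibition and higher numbers for weaker inhibition. Compound 1 (`COc1ccc(C2=C(CN3CCN(c4ccc(C(=O)NS(=O)(=O)c5ccc(NCC6CCOCC6)c([N+](=O)[O-])c5)c(Oc5cnc6[nH]ccc6c5)c4)CC3)CCC(C)(C)C2)cc1`) gives 12 nM there, and compound 2 (`CC(C)C(=O)N1CCC(CNc2ccc(S(=O)(=O)NC(=O)c3ccc(N4CCN(CC5=C(c6ccc(C(F)(F)F)cc6)CC(C)(C)CC5)CC4)cc3Oc3cnc4[nH]ccc4c3)cc2[N+](=O)[O-])CC1`) gives 5.3 nM. Compound 3 (`CC1(C)CCC(CN2CCN(c3ccc(C(=O)NS(=O)(=O)c4ccc(NC5CCOC5)c([N+](=O)[O-])c4)c(Oc4cnc5[nH]ccc5c4)c3)CC2)=C(c2ccc(C(F)(F)F)cc2)C1`) gives 32 nM as the highest number of the three, which makes it the weakest of this small set.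

Compound 4 (`CC1(C)CCC(CN2CCN(c3ccc(C(=O)NS(=O)(=O)c4ccc(OCC5CCCOC5)c([N+](=O)[O-])c4)c(Oc4cnc5[nH]ccc5c4)c3)CC2)=C(c2ccc(C(F)(F)F)cc2)C1`) differs from compound 3 in a single place, on an aromatic carbon ortho to a nitro group (a group of 8 heavy atoms (6 carbon, 2 oxygen; one six-membered non-aromatic ring with 1 hetero atom) in place of a group of 6 heavy atoms (4 carbon, 1 nitrogen, 1 oxygen; one five-membered non-aromatic ring with 1 hetero atom), on an aromatic carbon). A six-membered non-aromatic ring replaces a five-membered one, and the nitrogen on the aromatic ring is gone.

Within the data shown here, the one measured step at this place is a 6.0-fold higher number from compound 2 to compound 3 (0.78 log units; beyond the scatter) and it kept that nitrogen. Among the measured compounds shown here, it shows that the group here can move the number, but no measured compound has this nitrogen replaced. Compound 1 differs from compound 3 in more than one place, so its value does not isolate this change.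

With so little direct evidence, only a small rise is expected, and it may stay within the scatter. The expected change is a 1.6-fold higher number from compound 3 to compound 4 (0.19 log units; within the scatter) in this assay with wide uncertainty. The estimate for compound 4 is 50 nM with an expected range of 12 nM to 200 nM on this measure.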

Compound 4, half-maximal inhibitory concentration: 12 nM
For compound 4 the middle estimate is 4.2-fold (0.62 log units) above the measured one, within the range that was stated.
By their numbers in this assay, from the lowest: compound 2; then compounds 1 and 4 (each within the scatter of the next); then compound 3.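

Replacing the (oxolan-3-yl)amino group with the larger group joined through oxygen gives a 2.7-fold lower number from compound 3 to compound 4 (0.43 log units; beyond the scatter) in this assay. This shows that, in this pair, the position does not need a nitrogen on the aromatic ring, and that a group with no hydrogen-bond donor can sit there with stronger inhibition rather than weaker. Among these compounds, the earlier step at this place kept that nitrogen and could show only that the group attached to it can move the number, and nothing available here explains why this new change lowers the number.

The atom linking the group to the ring, the ring size and the overall size of the group all changed together, so this single step cannot be divided among them. An amine link carrying the same six-membered ring, or an ether link carrying the five-membered oxolane ring, would help to separate these effects, while a thioether link or a plain methoxy group on this aromatic carbon would test how much the link and the ring contribute.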